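Removing the Tolyl Methyl From an Ester-Bearing Scaffold

The source may report more compounds than this note shows. Statements on the series, on what has been measured and on what is new or still open speak of the compounds shown alone.

Within the data shown here, compound 3 `Cc1ccc(C(=O)OC2CCC(CN3CCN(c4cc(=O)c5cc(C(F)(F)F)cc([N+](=O)[O-])c5s4)CC3)CC2)cc1` is the only compound among the three measured that returns a number in an ADME assay on cells (Hepatocyte, Homo sapiens) for metabolic stability; on this read-out lower numbers stand for a shorter-lived compound and higher numbers for a longer-lived compound; compound 3 gives 0.148 h. Compound 1 `CS(=O)(=O)NC1CCC(CN2CCN(c3cc(=O)c4cc(C(F)(F)F)cc([N+](=O)[O-])c4s3)CC2)CC1` reaches only a limit of the assay, > 1.55 h. Compound 2 `CC(=O)NC1CCC(CN2CCN(c3cc(=O)c4cc(C(F)(F)F)cc([N+](=O)[O-])c4s3)CC2)CC1` likewise sits at a limit, > 1.55 h, and the limit of > 1.55 h in this assay, at which 2 of the 3 values shown sit, marks where both rest. The steps that reach compound 3 are large: an at least 10-fold lower number from compound 1 to compound 3 (1.02 log units; beyond the scatter) and an at least 10-fold lower number from compound 2 to compound 3 (1.02 log units; beyond the scatter). Compound 4 `O=C(OC1CCC(CN2CCN(c3cc(=O)c4cc(C(F)(F)F)cc([N+](=O)[O-])c4s3)CC2)CC1)c1ccccc1` differs from compound 3 by hydrogen in place of methyl on an aromatic carbon. Among the measured compounds shown here, none of the measured steps touches this position on the ring, so no step bears on the change; the expected step is a 1.4-fold higher number from compound 3 to compound 4 (0.13 log units; within the scatter), none beyond the scatter. Compound 4 is therefore estimated at 0.2 h, between 0.09 h and 0.45 h.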

Compound 4, half-life: 0.603 h
Beside the measured number, compound 4's estimate is 3.0-fold (0.48 log units) below it, and the stated range ends below it.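

this assay gives a reading at this position for the first time: there is a 4.1-fold higher number from compound 3 to compound 4 (0.61 log units; beyond the scatter), so the methyl on an aromatic carbon, para to a large group, is not a silent site. Hydrogen there still does not match acetamido or methanesulfonamido on the saturated ring carbon, with an at least 2.5-fold lower number from compound 2 to compound 4 (0.41 log units; beyond the scatter) and an at least 2.5-fold lower number from compound 1 to compound 4 (0.41 log units; beyond the scatter). Both of these steps are open-ended, resting on a limit of the assay: the limit of > 1.55 h in this assay, at which 2 of the 4 values shown sit.

On these data alone, it remains open whether a fluorine or a methoxy group on this aromatic carbon would track hydrogen or methyl. Also open, as far as these compounds go, is whether a benzamide would keep the number that benzoyloxy gives.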